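Aryl in place of cycloalkyl on the amide nitrogen

The compounds below may be only part of what the source reports. "The series", "measured", "known", "first", "only" and "open" are said of these compounds alone.

Compound 1, `CC1CCCCC1N(CCCCCCN1C[C@H](O)[C@@H](O)[C@H](O)[C@H]1CO)C(=O)OC(C)(C)C`, in an ADME assay on MDBK cells (Bos taurus) for cytotoxicity, read by MTT assay (on this read-out higher numbers stand for lower toxicity in this test and lower numbers for higher toxicity in this test), gives 250000 nM.
Compound 2, `CC1CCCCC1N(CCCCCCN1C[C@H](O)[C@@H](O)[C@H](O)[C@H]1CO)C(=O)C(C)(C)C`, in this assay reaches only the limit > 500000 nM.
Compound 3, `CC(=O)N(CCCCCCN1C[C@H](O)[C@@H](O)[C@H](O)[C@H]1CO)C1CCCCC1`, in this assay likewise reaches only the limit > 500000 nM.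

The three compounds share the same core; they differ in what sits on the amide-type nitrogen and on its carbonyl. For compound 2 the readout is a limit and not a number, so its place among the measured compounds is known only as a bound; this holds for two of the three values, as the limit of > 500000 nM in this assay, at which 2 of the 3 values shown sit, shows. For the measured compounds named here, the single step with two measured ends is an at least 2.0-fold higher number from compound 1 to compound 2 (0.30 log units; that floor lies within the scatter), and its floor lies within the scatter, so it tells little about direction.

Compound 4, `CC(C)(C)C(=O)N(CCCCCCN1C[C@H](O)[C@@H](O)[C@H](O)[C@H]1CO)c1cc(F)ccc1F`, is not yet measured. It differs from compound 2 by 2,5-difluorophenyl in place of 2-methylcyclohexyl on an amide-type nitrogen. Going by the values given here, no measured step touches the group on the amide-type nitrogen, so there is no step to lean on for this change. The measured compounds sit at or near the limit of this assay, and compound 4 is expected to stay in that region; the step from compound 2 is estimated as an at least 1.1-fold lower number from compound 2 to compound 4 (0.04 log units; that floor lies within the scatter). For compound 4 the expected value is 450000 nM, in the range 120000 nM to 1000000 nM.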

Compound 4, half-maximal cytotoxic concentration: > 500000 nM
Compound 4: no number, only a limit; the forecaster's own chance of this, stated with the estimate: 55%; at least 1.1-fold (0.04 log units) between middle value and limit.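

In this assay compound 4 gives > 500000 nM as a limit and not a number. For the compounds shown here, compound 2 also stands at a limit, so no step from compound 2 to compound 4 can be read: the limit of > 500000 nM in this assay, at which 3 of the 4 values shown sit.

The compounds shown leave open how far this assay would separate 2,5-difluorophenyl from 2-methylcyclohexyl on an amide-type nitrogen.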